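The source may hold more compounds than are shown below. What is called first, only, known or untested is meant among the compounds shown, and "the series" means these compounds.

Compound 1 `CCc1cccc2c(OC)c(-c3occ(C)c3CO)ccc12` is the parent of the pair. In a functional assay on MDA-MB-231 cells (Homo sapiens) for cytotoxicity, read by MTT assay, with a stated time of 72 h (on this read-out lower numbers stand for an effect already at smaller amounts and higher numbers for an effect only at larger amounts of compound), compound 1 reports only the assay limit, > 10 ug/mL, and no number. Among the measured compounds shown here, compound 2 `CCOCc1c(C)coc1-c1ccc2c(CC)cccc2c1OC` carries ethyl in place of hydrogen on the oxygen on the saturated carbon and gives 9.1 ug/mL in this assay, the sole number in the set. The remaining value is a limit. The step of an at least 1.0-fold lower number from compound 1 to compound 2 (0.04 log units; that floor lies within the scatter) is therefore bounded only at its floor, because the limit of > 10 ug/mL in this assay, at which 1 of the 2 values shown sits, fixes where that floor sits. Compound 3 `CCc1cccc2c(OC)c(-c3occ(C)c3CBr)ccc12` differs from compound 2 by bromo in place of ethoxy on a saturated chain carbon bound to an aromatic carbon. For the measured compounds named here, the single measured step touches the same saturated carbon but alters only the substituent on its oxygen, and it stays within the scatter; no measured step removes that oxygen or brings a halogen onto that carbon, so the earlier step gives little guidance here. The expectation is nonetheless written as a move toward lower numbers, with wide bounds on both sides. Compound 3 is estimated at 3 ug/mL in this assay, within 0.8 ug/mL to 12 ug/mL, which corresponds to an expected step of a 3.0-fold lower number from compound 2 to compound 3 (0.48 log units; beyond the scatter).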

Compound 3, concentration for half-maximal effect: 4.6 ug/mL
Compound 3: the middle estimate sits 1.5-fold (0.19 log units) below what was measured; low and high end bracket the measured number.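

Taking the oxygen off the saturated chain carbon bound to an aromatic carbon altogether, ethoxymethyl to bromomethyl, gives in this assay a 2.0-fold lower number from compound 2 to compound 3 (0.30 log units; within the scatter), so this exchange does not separate the ether from the bromide on this read-out. Set against the free hydroxy group, bromo gives an at least 2.1-fold lower number from compound 1 to compound 3 (0.33 log units; beyond the scatter), the first step at this position that is printed as beyond the scatter, whereas the earlier ethyl on the oxygen stayed within it at its floor. This step too is only a floor, and its full size stays unknown because the parent, compound 1, stands at a limit: the limit of > 10 ug/mL in this assay, at which 1 of the 3 values shown sits.

The compounds shown carry only hydroxy, ethoxy and bromo on this carbon, which leaves open how an amine, a chloro group or a longer ether chain would read there in this assay. On these data alone, the rest of the shared core stays the same in all three compounds, so whether the bromo-for-hydroxy step holds with other groups on that core also remains open.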